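A few compounds are considered here, and "the series" means these few. Any claim that something is new, unique, unknown or untested is made for them only; others in the source may bear on it.

Measured so far:
- Compound 1 `O=C(Nc1cc(F)cc(F)c1)c1cc(=O)[nH]c2cc(Br)ccc12` gives 10700 nM
- Compound 2 `COc1ccc2c(C(=O)Nc3cc(F)cc(F)c3)cc(=O)[nH]c2n1` gives > 20000 nM (a limit of the assay, not a number)
- Compound 3 `O=C(Nc1cccc(F)c1)c1cc(=O)[nH]c2cc(-c3ccccc3)ccc12` gives > 20000 nM (a limit of the assay, not a number)

These results come from a functional assay on KYSE-70 cells for antiproliferative activity against KYSE-70 cell line (Homo sapiens), read by MTT assay, with a stated time of 72 h; on this read-out lower numbers stand for stronger inhibition and higher numbers for weaker inhibition. Only compound 1 has an actual number. Compound 3 stands at the limit of > 20000 nM in this assay, at which 2 of the 3 values shown sit, so it has no exact position on the scale.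

Compound 4 `O=C(Nc1cccc(F)c1)c1cc(=O)[nH]c2cc(-c3cccc(F)c3)ccc12` differs from compound 3 in a single place: fluoro in place of hydrogen on an aromatic carbon. This is fluoro in place of hydrogen on an aromatic carbon, which turns phenyl to 3-fluorophenyl.

Among the compounds with values here, no two measured compounds differ in only one place, so the data give no direct guide to the size of this change. The expectation in this assay is therefore for no shift beyond the usual scatter, in either direction, and the expected step is a step that the limit leaves unreadable from compound 3 to compound 4. A further limit rather than a number is quite likely. For compound 4 the estimated value is 22000 nM, with an expected range from 9000 nM to 50000 nM.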

Compound 4, half-maximal inhibitory concentration: 12000 nM
Compound 4: middle estimate off by 1.8-fold (0.26 log units), on the high side; the range from low to high includes it.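

In this assay, the change from phenyl to 3-fluorophenyl brings an at least 1.6-fold lower number from compound 3 to compound 4 (0.22 log units; that floor lies within the scatter). Within the data shown here, this gives a first look at this position, where adding a single fluoro group yields a measured number rather than a limit, although the step's floor alone does not establish a real gain. Compound 3 has only a limit of the assay and not a number, so the true size of the step cannot be read: the limit of > 20000 nM in this assay, at which 2 of the 4 values shown sit.

The compounds shown leave open whether an amine or a carboxylic acid in place of the fluoro group on this ring would lower the number further. They also leave open whether the same change from phenyl to 3-fluorophenyl would give a similar step in a compound with a different amide partner.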